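This account rests on a few compounds, and the source may have more. Where it says the series, first, only, none or still open, it means among the compounds named here.

Measured in an ADME assay on Raji cells (Homo sapiens) for cytotoxicity, read by CellTiter-Glo and resazurin assay, with a stated time of 72 h; a lower number here means that less compound is needed, a higher number that more compound is needed for the effect:
- compound 1 `COc1ccc(F)c(-c2ccc(C(=O)N(Cc3cccc(OCCCCCC(=O)O)c3)C(C)C)cc2)c1`: > 26000 nM
- compound 2 `CC(C)N(Cc1cccc(OCCCCCC(=O)O)c1)C(=O)c1ccc(-c2cccc(C(F)(F)F)c2)cc1`: > 26000 nM

Compound 2 gives > 26000 nM, which is a limit and not a number. Compound 1 gives > 26000 nM, which is also a limit. Compound 3 `CC(C)N(Cc1cccc(OCCCCCC(=O)O)c1)C(=O)c1ccc(-c2cccc(Cl)c2)cc1` carries chloro in place of trifluoromethyl on an aromatic carbon, meta to a large group: chloro in place of trifluoromethyl on an aromatic carbon. Among the measured compounds shown here, the only measured step also swaps a group on an aromatic carbon, and it is a step that the two limits leave unreadable from compound 1 to compound 2, so it offers no size to carry over. What remains is the limit of > 26000 nM in this assay, at which 2 of the 2 values shown sit. On that basis, compound 3 is expected to stay at this limit in this assay as well. The estimated change is a step that the limit leaves unreadable from compound 2 to compound 3, and no shift in either direction beyond the scatter is expected. For compound 3 the estimate is 30000 nM, with an expected range of 12000 nM to 60000 nM.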

Compound 3, half-maximal effective concentration: > 21900 nM
Compound 3 was reported as a limit (the forecaster's own chance of this, stated with the estimate: 85%); the middle value lies beyond the limit too.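

Among the compounds shown here, compound 2 and compound 3 are both reported only as limits in this assay, as is compound 1, so no step among the three can be read. The compounds shown leave open how much of each is needed for the effect, and whether chloro in place of trifluoromethyl changes that amount at all.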